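The compounds below may be only part of what the source reports. "The series", "measured", "known", "first", "only" and "open" are said of these compounds alone.

Measured compounds:
compound 1, `Nc1nc(O)c2c(n1)n(C1OC(CO)[C@@H](O)[C@H]1O)c(=O)n2Cc1ccc([N+](=O)[O-])cc1`, with 147%
compound 2, `N#Cc1cccc(Cn2c(=O)n(C3OC(CO)[C@@H](O)[C@H]3O)c3nc(N)nc(O)c32)c1`, with 16%

Going by the values given here, in a functional assay on the whole organism (B cells) with Mus musculus as the target (a lower number here means a smaller maximal response, a higher number a larger maximal response), compound 2 stands lowest of the two numbers known, and its only neighbour is compound 1, whose value lies well above it. Among the compounds with values here, the one measured step is a number 131 percentage points lower from compound 1 to compound 2 (beyond the scatter), the exchange of 4-nitrophenyl for 3-cyanophenyl on a saturated chain carbon bound to an aromatic nitrogen. Compound 3, `Nc1nc(O)c2c(n1)n(C1OC(CO)[C@@H](O)[C@H]1O)c(=O)n2CCN1CCCCC1`, has not been measured. It differs from compound 2 by (piperidin-1-yl)methyl in place of 3-cyanophenyl on a saturated chain carbon bound to an aromatic nitrogen. The measured step bears on it only insofar as it concerns the same place and shows that changing the group there can move the maximal response by a very large amount; it compares two aromatic groups, whereas compound 3 carries a non-aromatic ring, so it gives no direction. Compound 3 is therefore expected to differ from compound 2 by a step that may well lie beyond the scatter, in either direction, namely a number 44 percentage points higher from compound 2 to compound 3 (beyond the scatter). Compound 3 is estimated at 60%, within a range from 10% to 150%.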

Compound 3, largest response reached (reported as maximal response), in percent of the reference or control that the assay uses: 0%
Estimate against measurement, compound 3: 60 percentage points above, and the stated range ends above it.
By their numbers in this assay, from the lowest: compound 3; then compound 2; then compound 1.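

In this assay the step is a number 16 percentage points lower from compound 2 to compound 3 (beyond the scatter) and, against the other aromatic group, a number 147 percentage points lower from compound 1 to compound 3 (beyond the scatter) for the same exchange, so the non-aromatic (piperidin-1-yl)methyl group stands below both aromatic groups at this place on a saturated chain carbon bound to an aromatic nitrogen. Going by these compounds alone, the earlier pair showed only that two aromatic groups could lie far apart here; the third compound shows that compound 2 lies much closer to compound 3 than to compound 1, which leaves the high response of compound 1 standing alone among the three. Nothing available accounts for this order.

Compounds 1 and 2 differ both in the substituent on the phenyl ring and in where it sits, so a 4-cyanophenyl group would be needed to tell these two changes apart. As far as these compounds go, it also remains open whether the low response extends to other amines on the chain, such as an open-chain dimethylamino group or a piperidine ring held on a longer chain.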